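A few compounds are considered here, and "the series" means these few. Any claim that something is new, unique, unknown or untested is made for them only; others in the source may bear on it.

Compound 1 `O=[N+]([O-])c1ccc(N2CCNCC2)cc1NCc1ccccc1`: 28 nM
Compound 2 `CN1CCN(c2ccc([N+](=O)[O-])c(NC(c3ccccc3)c3ccccc3)c2)CC1`: 4490 nM

In an assay on HEK293 cells for displacement of a labelled ligand from 5-hydroxytryptamine receptor 6 (Homo sapiens) (a higher number here means a weaker inhibitor, a lower number a stronger inhibitor), compound 1 gives 28 nM, the lowest of the two numbers in hand; compound 2 gives 4490 nM, a far higher number, and the two differ at more than one place. Compound 3 `O=[N+]([O-])c1ccc(N2CCNCC2)cc1NCCOc1ccccc1` is derived from compound 1 by a single change, (phenoxymethyl in place of phenyl on a saturated chain carbon bound to a nitrogen on an aromatic ring). Among the measured compounds shown here, no step between measured compounds shows the effect of such a change. A step upward beyond the scatter is expected, a 4.3-fold higher number from compound 1 to compound 3 (0.63 log units; beyond the scatter), since the entering group is longer than the leaving one. For compound 3 in this assay the estimate is 120 nM, ranging from 30 nM to 500 nM.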

Compound 3, inhibition constant: 114 nM
Compound 3: middle estimate off by 1.1-fold (0.02 log units), on the high side; measured number inside the range.
By their numbers in this assay, from the lowest: compound 1; then compound 3; then compound 2.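

In this assay, among the compounds shown here, phenoxymethyl in place of phenyl on a saturated chain carbon bound to a nitrogen on an aromatic ring gives a 4.1-fold higher number from compound 1 to compound 3 (0.61 log units; beyond the scatter), the first step here that isolates a single change. The step is modest, and the longer group leaves compound 3 at 114 nM, so this position accepts the change without a collapse on the scale of compound 2. No measurement at hand accounts for the step. The compounds shown do not separate the added length from the added oxygen, which a phenylethyl group would test. On these data alone, how an amine at this place would compare also remains open.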